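Placing a 4-cyanobenzyl group on the shared core

The source may report more compounds than this note shows. Statements on the series, on what has been measured and on what is new or still open speak of the compounds shown alone.

Of the compounds shown here, three of one shared core have been measured in a functional assay (B cells) with Mus musculus as the target; on this read-out lower numbers stand for an effect already at smaller amounts and higher numbers for an effect only at larger amounts of compound. Compound 3 `Cn1c(=O)n(C2OC(CO)[C@@H](O)[C@H]2O)c2nc(N)nc(O)c21` gives 10 uM and stands at the lowest number of the three; compound 1 `CCn1c(=O)n(C2OC(CO)[C@@H](O)[C@H]2O)c2nc(N)nc(O)c21` gives 15 uM, and the step of a 1.5-fold lower number from compound 1 to compound 3 (0.18 log units; within the scatter) lies within the scatter, so the two cannot be told apart. Compound 2 `COc1ccc(Cn2c(=O)n(C3OC(CO)[C@@H](O)[C@H]3O)c3nc(N)nc(O)c32)cc1` gives 135 uM, and the step of a 14-fold lower number from compound 2 to compound 3 (1.13 log units; beyond the scatter) is the one clear difference in this set.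

Compound 4 `N#Cc1ccc(Cn2c(=O)n(C3OC(CO)[C@@H](O)[C@H]3O)c3nc(N)nc(O)c32)cc1` is the next step from compound 3: 4-cyanophenyl in place of hydrogen on a saturated chain carbon bound to an aromatic nitrogen. This change closely resembles the reverse of the step from compound 2 to compound 3, where a 4-methoxyphenyl at the same place gave the large shift noted above; the step of a 9.0-fold higher number from compound 1 to compound 2 (0.95 log units; beyond the scatter) points the same way. For the measured compounds named here, a step of roughly that size toward higher numbers is therefore expected, though only one carrying group has been measured, so the match is uncertain. Compound 4 is expected to give 100 uM, between 35 uM and 300 uM, an expected step of a 10-fold higher number from compound 3 to compound 4 (1.00 log units; beyond the scatter).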

Compound 4, concentration for half-maximal effect: 15 uM
Compound 4: middle estimate off by 6.7-fold (0.82 log units), on the high side; the measured number lies below the stated range.
By their numbers in this assay, from the lowest: compounds 3, 1 and 4 (each within the scatter of the next); then compound 2.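

In this assay a 4-cyanobenzyl group on this nitrogen is tolerated: the step (a 1.5-fold higher number from compound 3 to compound 4 (0.18 log units; within the scatter)) and the step (no change at the digits printed from compound 1 to compound 4 (within the scatter)) both lie within the scatter, so compound 1, compound 3 and compound 4 cannot be told apart. The high number of compound 2 therefore does not apply to every benzyl group at this place, since cyano in place of methoxy on an aromatic carbon gives a clear difference (a 9.0-fold lower number from compound 2 to compound 4 (0.95 log units; beyond the scatter)). No measurement here explains why these two groups behave differently.

With only methoxy and cyano on the ring, the compounds shown cannot separate the effect of the ring from that of the group it carries. As far as these compounds go, a plain benzyl group, a benzyl group carrying a carboxylic acid or an amine, and a longer chain such as propyl all remain open.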